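The source may hold more compounds than are shown below. What is called first, only, known or untested is meant among the compounds shown, and "the series" means these compounds.

Compounds measured so far:
compound 1, `Cc1ccnc(/C(N)=N/NC(=S)N2CCCCCC2)c1` — 91.6%
compound 2, `N/C(=N\NC(=S)N1CCN(c2ccccn2)CC1)c1ccc(F)cn1` — 83%
compound 3, `Cc1cccc(/C(N)=N/NC(=S)N2CCCC2)n1` — 80.1%

All three values come from a functional assay on HeLa cells (Homo sapiens) for cytotoxicity, read by MTT assay, with a stated time of 72 h, tested at 100 uM; a lower number here means less inhibition of growth, a higher number more inhibition of growth at the concentration tested. Compound 2 stands second highest of the three numbers; its value lies within the scatter of compound 3 and also within the scatter of compound 1, so the three compounds cannot be told apart on these numbers.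

Compound 4, `Cc1cccc(/C(N)=N/NC(=S)N2CCN(c3ccccn3)CC2)n1`, has not yet been measured in this assay. It differs from compound 2 in one place: 6-methylpyridin-2-yl in place of 5-fluoropyridin-2-yl on a carbon with a double bond to nitrogen.

For the measured compounds named here, no pair of measured compounds differs in a single place, so no measured step is available. With all three measured values close together, the change from compound 2 to compound 4 is expected to give no step beyond the scatter, no change at the digits printed from compound 2 to compound 4 (within the scatter). Compound 4 is estimated at 83%, in a range from 70% to 93%.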

Compound 4, percent growth inhibition at one concentration: 86.3%
Estimate against measurement, compound 4: 3.3 percentage points below; low and high end bracket the measured number.
By their numbers in this assay, from the lowest: compounds 3, 2, 4 and 1 (each within the scatter of the next, the first and the last beyond it).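

In this assay the first single-place comparison gives a number 3.3 percentage points higher from compound 2 to compound 4 (within the scatter) for 6-methylpyridin-2-yl in place of 5-fluoropyridin-2-yl on a carbon with a double bond to nitrogen. At this place, then, the two rings cannot be told apart, and growth inhibition at this one concentration does not depend on which of them is present. No measurement at hand explains this result.

From the compounds shown here alone, whether a pyridin-2-yl carrying a methoxy group or an amine would give a similar number stays open. So does whether the two rings would differ at lower concentrations.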